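Removing the methyl from compound 2's methoxy group

This account rests on a few compounds, and the source may have more. Where it says the series, first, only, none or still open, it means among the compounds named here.

Among the measured compounds shown here, compound 2 `COc1cc(-c2nn(-c3cccc(NC(=O)Nc4cc(C(F)(F)F)cc(C(F)(F)F)c4)c3)cc2-c2ccncc2)ccc1Cl` is the only one of three compounds to give a number in a functional assay on NCI-H460 cells (Homo sapiens) for inhibition, read by sulforhodamine B assay, with a stated time of 48 h; on this read-out lower numbers stand for higher toxicity in this test and higher numbers for lower toxicity in this test: compound 2 shows 16300 nM. Compound 1 `O=C(Nc1cccc(-n2cc(-c3ccncc3)c(-c3ccc(Cl)c(O)c3)n2)c1)Nc1cccc(C(F)(F)F)c1` reaches only a limit of the assay, > 32500 nM. Compound 3 `COc1cc(-c2nn(-c3cccc(NC(=O)Nc4cccc(C(F)(F)F)c4)c3)cc2-c2ccncc2)ccc1Cl` likewise stops at a limit, > 50000 nM. Of the two measured steps, an at least 3.0-fold higher number from compound 2 to compound 3 (0.48 log units; beyond the scatter) is at least modest, while a step that the two limits leave unreadable from compound 1 to compound 3 cannot be read because both ends are limits the limit of > 32500 nM in this assay, at which 1 of the 3 values shown sits (the limit of > 50000 nM in this assay, at which 1 of the 3 values shown sits). Compound 4 `O=C(Nc1cccc(-n2cc(-c3ccncc3)c(-c3ccc(Cl)c(O)c3)n2)c1)Nc1cc(C(F)(F)F)cc(C(F)(F)F)c1` differs from compound 2 by hydrogen in place of methyl on an oxygen on an aromatic ring, the reverse of the unreadable step. No readable step therefore bears on it, and no step beyond the scatter is expected from compound 2 to compound 4 in this assay. Compound 4 is estimated at 18000 nM, between 7000 nM and 45000 nM, meaning a 1.1-fold higher number from compound 2 to compound 4 (0.04 log units; within the scatter).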

Compound 4, concentration lethal to 50% of the cells: 4860 nM
Estimate against measurement, compound 4: 3.7-fold (0.57 log units) above; the measured number lies below the stated range.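

With compound 4, the change from methoxy to hydroxy gains its first readable size in this assay, a 3.4-fold lower number from compound 2 to compound 4 (0.53 log units; beyond the scatter), whereas the same change between the compounds carrying one trifluoromethyl cannot be read. The step of an at least 6.6-fold lower number from compound 1 to compound 4 (0.82 log units; beyond the scatter) shows that a trifluoromethyl in place of hydrogen also goes with a lower number on the core of compound 1, matching the direction seen on the core of compound 3: the same change on two cores in this assay, an at least 3.0-fold higher number (0.48 log units; beyond the scatter) from compound 2 to compound 3 and an at least 6.6-fold higher number (0.82 log units; beyond the scatter) from compound 4 to compound 1; the limit leaves it open whether they differ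

As far as these compounds go, whether the hydroxy change has any size with a single trifluoromethyl remains open. So does the outcome with an amine or a longer ether chain at this position.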